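This account rests on a few compounds, and the source may have more. Where it says the series, first, only, none or still open, it means among the compounds named here.

Of the compounds shown here, two sharing one core have been tested in a functional assay on UACC-62 cells (Homo sapiens) for cytotoxicity, read by sulforhodamine B assay; on this read-out lower numbers stand for stronger inhibition of growth and higher numbers for weaker inhibition of growth. Compound 1 (`CC1=CC[C@@H]([C@@](C)(O)CCCC(C)(C)NC(=S)N/N=C\c2ccccc2[N+](=O)[O-])CC1`) gives 16600 nM, while compound 2 (`CC1=CC[C@@H]([C@@](C)(O)CCCC(C)(C)NC(=S)N/N=C\c2ccc([N+](=O)[O-])cc2)CC1`) gives 62200 nM, the higher number of the two and so the weaker inhibition of growth. Compound 3 (`CC1=CC[C@@H]([C@@](C)(O)CCCC(C)(C)NC(=S)N/N=C\c2ccc(Cl)cc2)CC1`) keeps the shared core but carries chloro in place of nitro on an aromatic carbon, para to a large group: chloro in place of nitro on an aromatic carbon. Among the compounds with values here, the only measured step, a 3.7-fold higher number from compound 1 to compound 2 (0.57 log units; beyond the scatter), relocates the nitro group and does not replace it, so it bears on this change only indirectly. Within the data shown here, no chloro compound has yet been measured, so no change beyond the scatter is expected, with only a slight lean towards a lower number. The expected step is a 1.6-fold lower number from compound 2 to compound 3 (0.19 log units; within the scatter). For compound 3 the estimated value is 40000 nM, with an expected range from 15000 nM to 100000 nM.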

Compound 3, concentration for total growth inhibition: 13800 nM
The estimate for compound 3 lay 2.9-fold (0.46 log units) above the measured number; measured number outside the range, below it.
By their numbers in this assay, from the lowest: compounds 3 and 1 (each within the scatter of the next); then compound 2.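

In this assay the change to chloro on this aromatic carbon, para to a large group, gives a 4.5-fold lower number from compound 2 to compound 3 (0.65 log units; beyond the scatter) and so shows that the read-out here depends on which group the carbon carries, whereas the earlier step only relocated the nitro group. The comparison of the 2-nitrophenyl and 4-chlorophenyl compounds gives a 1.2-fold lower number from compound 1 to compound 3 (0.08 log units; within the scatter) and places them within the scatter of each other, so the weaker inhibition of growth seen with compound 2 does not extend to compound 3. No measurement offers an explanation for the difference between nitro and chloro at this position. The compounds shown leave open whether a methoxy group or an amine on this aromatic carbon would track chloro or nitro, and whether bromo would match chloro.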